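The source may hold more compounds than are shown below. What is called first, only, known or untested is meant among the compounds shown, and "the series" means these compounds.

Compound 1 `O=C(Nc1c(F)cc(F)cc1F)N(Cc1ccc(-c2ccsc2)cc1)C1CCCCCC1`: a limit of > 1 mg/kg
Compound 2 `O=C(Nc1c(F)cc(F)cc1F)N(Cc1ccc(-n2cccc2)cc1)C1CCCCCC1`: a limit of > 1 mg/kg

In a functional assay on a cell-free system (plasma) with sterol O-acyltransferase, Soat (Rattus norvegicus) as the target (a lower number here means that less compound is needed, a higher number that more compound is needed for the effect), compound 1 gives only a limit of the assay, > 1 mg/kg. Compound 2 gives only a limit in this assay as well, > 1 mg/kg. Among the measured compounds shown here, the one step between them, a step that the two limits leave unreadable from compound 1 to compound 2, therefore cannot be read in size or direction. For the measured compounds named here, compound 2 thus stands at a limit, and the only other value shown is a limit too; both sit at the limit of > 1 mg/kg in this assay, at which 2 of the 2 values shown sit.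

The unmeasured compound 3 `O=C(Nc1c(F)cc(F)cc1F)N(Cc1ccc(-c2ccccn2)cc1)C1CCCCCC1` differs from compound 2 by pyridin-2-yl in place of 1H-pyrrol-1-yl on an aromatic carbon. No measured step bears on this change with a readable size, since the sole step shown is hidden by two limits, so no size can be carried over and no direction is expected beyond the scatter. Compound 3 is expected to give 2 mg/kg, in a range from 0.5 mg/kg to 10 mg/kg, most likely again as a limit. The expected step from compound 2 to compound 3 is a step that the limit leaves unreadable from compound 2 to compound 3.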

Compound 3, dose for half-maximal effect: > 1 mg/kg
Compound 3: no number, only a limit; the forecaster's own chance of this, stated with the estimate: 80%; the middle value lies beyond the limit too.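

In this assay compound 3 gives > 1 mg/kg as a limit of the assay. Among the compounds shown here, no step among compound 1, compound 2 and compound 3 can be read in size or direction, since all three stand at one limit: the limit of > 1 mg/kg in this assay, at which 3 of the 3 values shown sit. The compounds shown leave open whether thiophen-3-yl, 1H-pyrrol-1-yl and pyridin-2-yl differ at all in this read-out.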